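Aryl ketone exchange in a growth-inhibition series

The source may hold more compounds than are shown below. What is called first, only, known or untested is meant among the compounds shown, and "the series" means these compounds.

Two compounds of the series carry numbers. In a functional assay on BT-549 cells (Homo sapiens) for inhibition, read by sulforhodamine B assay, with a stated time of 48 h (a higher number here means a weaker inhibitor of growth, a lower number a stronger inhibitor of growth), compound 1 `COc1ccc(-c2cc(/C=C/C(=O)c3ccc(N)cc3)[nH]n2)cc1` gives 4780 nM. Compound 2 `COc1cc(-c2cc(/C=C/C(=O)c3ccc(N)cc3)[nH]n2)cc(OC)c1OC` gives 2820 nM in this assay. Compound 2 thus holds the lowest of the two numbers, and compound 1 is its nearest neighbour, a difference that lies within the scatter, so the two compounds cannot be ordered against each other on these data.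

Compound 3 `COc1cc(-c2cc(/C=C/C(=O)c3ccc(Cl)c(Cl)c3)[nH]n2)cc(OC)c1OC` has not yet been measured in this assay. It differs from compound 2 in a single place: 3,4-dichlorophenyl in place of 4-aminophenyl on a carbonyl carbon. Within the data shown here, no step between measured compounds covers an exchange of this kind, and the only measured pair, compound 1 and compound 2, tells nothing about the ketone-bound aryl group. Among the measured compounds shown here, the move from compound 2 to compound 3 therefore rests on no measured precedent, and the expectation is a step of modest size, most likely not beyond the scatter, with a slight lean toward a lower number. Compound 3 is expected to give 2000 nM in this assay, with a range from 600 nM to 7000 nM. The expected step is a 1.4-fold lower number from compound 2 to compound 3 (0.15 log units; within the scatter).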

Compound 3, concentration for total growth inhibition: 29300 nM
Compound 3: middle estimate off by 15-fold (1.17 log units), on the low side; measured number outside the range, above it.
By their numbers in this assay, from the lowest: compounds 2 and 1 (each within the scatter of the next); then compound 3.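

The ketone-bound aryl group is the first place in the series shown to carry a step beyond the scatter: in this assay, 3,4-dichlorophenyl in place of 4-aminophenyl on a carbonyl carbon gives a 10-fold higher number from compound 2 to compound 3 (1.02 log units; beyond the scatter). Compound 1 and compound 2 both carry 4-aminophenyl there, so only compound 3 shows that the growth-inhibition number is sensitive to this exchange, and that this dichlorinated group, with no hydrogen-bond donor or acceptor, goes with the weaker inhibitor. Nothing measured on these compounds accounts for the size of the step.

Among these compounds, the single exchange removes the amine and brings in two chlorines at once, so it remains open whether an unsubstituted phenyl, or a phenyl bearing one chlorine or a hydroxyl, would stand with compound 2 or with compound 3. Also open, as far as these compounds go, is whether 3,4-dichlorophenyl on the core of compound 1 would give a step of similar size in this assay.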